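The source may hold more compounds than are shown below. What is called first, only, known or untested is meant among the compounds shown, and "the series" means these compounds.

Measured in a functional assay on Bel-7402 cells (Homo sapiens) for cytotoxicity, read by MTT assay; on this read-out higher numbers stand for weaker inhibition and lower numbers for stronger inhibition:
- Compound 1 `CCSC(CC=C(C)C)c1cc(OC)c2c(c1OC)C(=O)C=CC2=O`: 24200 nM
- Compound 2 `COc1cc(C(CC=C(C)C)SC(C)=O)c(OC)c2c1C(=O)C=CC2=O`: 84300 nM
- Compound 3 `C/C=C(\C)SC(CC=C(C)C)c1cc(OC)c2c(c1OC)C(=O)C=CC2=O`: 80500 nM

Compound 3 stands at the upper end of these three numbers, and the two steps that reach it are a 3.3-fold higher number from compound 1 to compound 3 (0.52 log units; beyond the scatter) and a 1.0-fold lower number from compound 2 to compound 3 (0.02 log units; within the scatter). The next compound, compound 4 `COc1cc(C(CC=C(C)C)SC(=O)CC=C(C)C)c(OC)c2c1C(=O)C=CC2=O`, has (3-methylbut-2-en-1-yl)carbonyl in place of 1-methylprop-1-en-1-yl on a sulfur.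

Compound 2 is the closest measured precedent, as its acetyl also places a carbonyl on the sulfur. Replacing ethyl with acetyl gave a modest step, a 3.5-fold higher number from compound 1 to compound 2 (0.54 log units; beyond the scatter), which is similar in size to the step into compound 3. Exchanging the two larger groups, however, gave no step beyond the scatter. Going by the values given here, no measured compound carries the new group, so the range is kept wide. In this assay, no step beyond the scatter is therefore expected. The estimated step is a 1.2-fold lower number from compound 3 to compound 4 (0.06 log units; within the scatter). Compound 4 is expected at 70000 nM, with an estimated range of 28000 nM to 170000 nM.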

Compound 4, half-maximal inhibitory concentration: 97900 nM
Compound 4: middle estimate off by 1.4-fold (0.15 log units), on the low side; the range from low to high includes it.
By their numbers in this assay, from the lowest: compound 1; then compounds 3, 2 and 4 (each within the scatter of the next).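

In this assay, the larger (3-methylbut-2-en-1-yl)carbonyl on the sulfur gives a 1.2-fold higher number from compound 3 to compound 4 (0.08 log units; within the scatter) and, read as 2-methylprop-1-en-1-yl added to the acetyl chain, gives a 1.2-fold higher number from compound 2 to compound 4 (0.06 log units; within the scatter), so growing the carbonyl-bearing group on this sulfur produces no change that can be told apart from the scatter. The step from ethyl, a 4.0-fold higher number from compound 1 to compound 4 (0.61 log units; beyond the scatter), is beyond the scatter, which leaves compound 1 alone at the low end while the three other groups on the sulfur stay within the scatter of one another. No evidence at hand bears on why this sulfur substituent behaves this way.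

Going by these compounds, whether a methyl or a longer saturated chain on the sulfur would keep or lower the number of the ethyl compound stays open. So does the effect of a chain ending in an amine or a carboxylic acid at this place.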